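The compounds below may be only part of what the source reports. "The series", "measured", "known", "first", "only" and "open" are said of these compounds alone.

Going by the values given here, compound 2 `Cn1nc(-c2ccnc(Nc3cccc(S(N)(=O)=O)c3)n2)c2ccccc21` gives 2270 nM in a functional assay on MCF7 cells (Homo sapiens) for antiproliferative activity, read by MTT assay, with a stated time of 72 h (on this read-out lower numbers stand for stronger inhibition of growth and higher numbers for weaker inhibition of growth), the highest of the two numbers measured so far; its nearest neighbour is compound 1 `Cn1nc(-c2ccnc(Nc3cccc([N+](=O)[O-])c3)n2)c2ccccc21`, which gives 580 nM in this assay. Among the compounds with values here, the one measured step, a 3.9-fold higher number from compound 1 to compound 2 (0.59 log units; beyond the scatter), concerns sulfamoyl in place of nitro on an aromatic carbon. Compound 3 `NS(=O)(=O)c1cccc(Nc2nccc(-c3nn(Cc4cccnc4)c4ccccc34)n2)c1` keeps the sulfamoyl group and differs from compound 2 by pyridin-3-yl in place of hydrogen on a saturated chain carbon bound to an aromatic nitrogen; the same difference, cut one bond further out, reads methyl to (pyridin-3-yl)methyl. Within the data shown here, no measured step touches this part of the shared core, so nothing in the data speaks directly to the change. With no relevant comparison available, compound 3 is expected to show a step of a 1.1-fold lower number from compound 2 to compound 3 (0.05 log units; within the scatter) that does not go beyond the scatter. The estimate for compound 3 in this assay is 2000 nM, with a range from 700 nM to 6000 nM.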

Compound 3, concentration for 50% growth inhibition: 5270 nM
For compound 3 the middle estimate is 2.6-fold (0.42 log units) below the measured one, and the stated range covers the measured number.
By their numbers in this assay, from the lowest: compound 1; then compound 2; then compound 3.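

In this assay, the change on the saturated chain carbon bound to an aromatic nitrogen gives a 2.3-fold higher number from compound 2 to compound 3 (0.37 log units; beyond the scatter), which shows that this part of the shared core also affects the read-out; the earlier step concerned only sulfamoyl and nitro on an aromatic carbon. Going from methyl to (pyridin-3-yl)methyl weakens growth inhibition modestly but does not abolish it. No measurement is available to explain this shift.

The compounds leave open whether pyridin-3-yl would produce a similar step with nitro in place of sulfamoyl, as it appears here only alongside sulfamoyl. They also leave open how this position would respond to a benzyl group, which lacks the ring nitrogen, or to a longer chain ending in an amine.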